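Changing the Halogenated Ring on the Amide Nitrogen

A few compounds are considered here, and "the series" means these few. Any claim that something is new, unique, unknown or untested is made for them only; others in the source may bear on it.

Measured so far:
compound 1 `O=C(CSc1nc(Nc2ccccc2)c2ccccc2n1)Nc1ccccc1Cl`: 24400 nM
compound 2 `O=C(CSc1nc(Nc2ccccc2)c2ccccc2n1)Nc1ccccc1Br`: 14100 nM

In a functional assay on MDA-MB-231 cells (Homo sapiens) for inhibition, read by MTT assay, with a stated time of 72 h (on this read-out lower numbers stand for stronger inhibition and higher numbers for weaker inhibition), compound 1 gives 24400 nM, the highest of the two numbers; in this assay compound 2 gives 14100 nM. Within the data shown here, the only measured step, a 1.7-fold lower number from compound 1 to compound 2 (0.24 log units; within the scatter), swaps one halogen for another at the same place. Compound 3 `O=C(CSc1nc(Nc2ccccc2)c2ccccc2n1)Nc1cccc(F)c1` instead carries 3-fluorophenyl in place of 2-chlorophenyl on an amide-type nitrogen. Among the measured compounds shown here, no measured step shows what moving the halogen and shrinking it to fluorine does, so the expected change from compound 1 to compound 3 is a 1.2-fold lower number from compound 1 to compound 3 (0.09 log units; within the scatter), none beyond the scatter. The estimate for compound 3 is therefore 20000 nM, within a range of 6000 nM to 70000 nM.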

Compound 3, half-maximal inhibitory concentration: > 50000 nM
Compound 3: only a limit was reported; the forecaster's own chance of this, stated with the estimate: 15%; at least 2.5-fold (0.39 log units) between middle value and limit.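

Compound 3 gives a limit of the assay, not a number: the limit of > 50000 nM in this assay, at which 1 of the 3 values shown sits.

Even so, the steps on the amide-type nitrogen can be read (from the first, an at least 2.0-fold higher number from compound 1 to compound 3 (0.31 log units; beyond the scatter); from the second, an at least 3.5-fold higher number from compound 2 to compound 3 (0.54 log units; beyond the scatter)). Unlike the swap of chloro for bromo, which stayed within the scatter, replacing either halogenated ring with 3-fluorophenyl gives a change beyond it, so this place does respond to what it carries.

The compounds shown do not separate the identity of the halogen from its place on the ring, as both change together. As far as these compounds go, how a ring carrying an amine or a carboxylic acid would behave here remains open.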